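The compounds below may be only part of what the source reports. "The series", "measured", "known", "first", "only" and "open" are said of these compounds alone.

Compound 2, `CO/N=C(/c1ccc(Cl)cc1)C(O)CN1CCN(c2ccccn2)CC1`, is the one with the higher of the two numbers in a functional assay on HEK293 cells with D(4) dopamine receptor (Homo sapiens) as the target, read by FLIPR; on this read-out lower numbers stand for smaller maximal responses and higher numbers for larger maximal responses: compound 2 gives 94%, and its nearest neighbour is compound 1, `CO/N=C(\c1ccc(Cl)cc1)C(O)CN1CCN(c2ccccn2)CC1`, which in this assay gives 89%. The two compounds differ only in how one double bond is drawn, and the step of a number 5 percentage points higher from compound 1 to compound 2 (within the scatter) is therefore no real change; the drawing itself, (the fact that one of compounds 1 and 2 is drawn with a defined configuration and the other without, at the place where they differ), is the only thing that sets them apart.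

Compound 3, `CO/N=C(/c1ccc(Cl)cc1)C(CN1CCN(c2ccccn2)CC1)OC`, is not yet measured. Compared with compound 2 it carries methyl in place of hydrogen on an oxygen on a saturated carbon. Going by the values given here, no measured step touches this position, so the only guide is that both measured compounds reach nearly the full response of the reference. A step of similar size or a modest loss is expected for compound 3 in this assay, a number 9 percentage points lower from compound 2 to compound 3 (within the scatter). Compound 3 is accordingly estimated to reach 85%, between 65% and 100%.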

Compound 3, largest response reached (reported as efficacy), in percent of the reference or control that the assay uses: 83%
Beside the measured number, compound 3's estimate is 2 percentage points above it; the measured number falls inside the stated range.
By their numbers in this assay, from the lowest: compounds 3, 1 and 2 (each within the scatter of the next, the first and the last beyond it).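

Going by these compounds alone, compounds 1 and 2 carry the same hydroxy group and so showed nothing about this position, whereas the change from hydroxy to methoxy in this assay gives a number 11 percentage points lower from compound 2 to compound 3 (beyond the scatter) as the first step to exceed the usual scatter. The step is modest: compound 3 still gives 83% and so keeps a large maximal response without the hydrogen on that oxygen. Nothing measured here gives a reason for this loss.

As far as these compounds go, whether a longer chain on this oxygen, such as ethyl or benzyl, would lower the response further remains open, as does the effect of an amine in place of the hydroxy group. From the compounds shown here alone, it is also open whether methoxy gives a step of the same size with the double bond drawn as in compound 1.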